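The source may hold more compounds than are shown below. What is called first, only, known or untested is meant among the compounds shown, and "the series" means these compounds.

Measured compounds:
- Compound 1, `COc1cc(Nc2ncnc3c(NC(=O)Nc4ccccc4Cl)cccc23)cc(OC)c1`: 356 nM
- Compound 2, `COc1cc(Nc2ncnc3c(NC(=O)Nc4ccc(C(F)(F)F)cc4)cccc23)cc(OC)c1`: 3920 nM
- Compound 3, `CCOC(=O)c1ccc(NC(=O)Nc2cccc3c(Nc4cc(OC)cc(OC)c4)ncnc23)cc1`: 317 nM

In a functional assay on RT-112 cells (Homo sapiens) for antiproliferative activity, read by MTT assay, with a stated time of 72 h (on this read-out higher numbers stand for weaker inhibition of growth and lower numbers for stronger inhibition of growth), compound 1 gives 356 nM, which is the second highest of the three numbers. Its nearest neighbour is compound 3, with 317 nM, and the step of a 1.1-fold lower number from compound 1 to compound 3 (0.05 log units; within the scatter) lies within the scatter. The furthest is compound 2, with 3920 nM, reached by the step of an 11-fold higher number from compound 1 to compound 2 (1.04 log units; beyond the scatter).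

Compound 4, `COc1cc(Nc2ncnc3c(NC(=O)c4ccc(CN(C)C)cc4)cccc23)cc(OC)c1`, has not yet been measured. It differs from compound 1 in one place: 4-((dimethylamino)methyl)phenyl in place of (2-chlorophenyl)amino on a carbonyl carbon. For the measured compounds named here, this removes the amide-type nitrogen that carried the aryl group in all three measured compounds, so none of the measured steps covers the change directly. Going by the values given here, the two steps from compound 1, an 11-fold higher number from compound 1 to compound 2 (1.04 log units; beyond the scatter) and a 1.1-fold lower number from compound 1 to compound 3 (0.05 log units; within the scatter), show only that changing the aryl group on that nitrogen can leave the number unchanged or raise it considerably, and a 12-fold lower number from compound 2 to compound 3 (1.09 log units; beyond the scatter) repeats the same range. With nothing on the loss of the nitrogen itself, the step of a 2.2-fold higher number from compound 1 to compound 4 (0.35 log units; beyond the scatter) is expected to be modest and is given a wide range. Compound 4 is therefore estimated at 800 nM in this assay, between 200 nM and 4000 nM.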

Compound 4, concentration for 50% growth inhibition: 4370 nM
Estimate against measurement, compound 4: 5.5-fold (0.74 log units) below, and the stated range ends below it.
By their numbers in this assay, from the lowest: compounds 3 and 1 (each within the scatter of the next); then compounds 2 and 4 (each within the scatter of the next).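

In this assay, the first change to remove the amide-type nitrogen, putting 4-((dimethylamino)methyl)phenyl on the carbonyl carbon, proves far from neutral, giving a 12-fold higher number from compound 1 to compound 4 (1.09 log units; beyond the scatter) and a 14-fold higher number from compound 3 to compound 4 (1.14 log units; beyond the scatter), so this position is not shown to accept every replacement of the aryl amino group. The step of a 1.1-fold higher number from compound 2 to compound 4 (0.05 log units; within the scatter) puts this change level with the 4-(trifluoromethyl)phenyl change, which keeps the amide-type nitrogen, so losing that nitrogen is not needed to reach a number of this size, while compounds 1 and 3 show that keeping it with a different aryl group can give a much lower one. No measurement at hand accounts for these steps.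

As far as these compounds go, what remains open is whether the higher number of compound 4 follows from the missing nitrogen, from the dimethylamino group on its methyl chain, or from both, since the two differences arrive together. A (4-((dimethylamino)methyl)phenyl)amino group on the same carbonyl carbon would address the first question, and an unsubstituted phenyl there would address the second.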